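This account rests on a few compounds, and the source may have more. Where it says the series, first, only, none or still open, it means among the compounds named here.

Measured compounds:
Compound 1 `CC1=C(/C=C/C(C)=C/C=C/C(C)=C\C(=O)Nc2ccccc2)C(C)(C)CC=C1c1cccnc1` gives 25100 nM in a functional assay on MDA-MB-231 cells (Homo sapiens) for inhibition, read by MTT assay; a lower number here means a stronger inhibitor of growth, a higher number a weaker inhibitor of growth.
Compound 2 `CC1=C(/C=C/C(C)=C/C=C/C(C)=C\C(=O)Nc2ccc(F)cc2)C(C)(C)CCC1n1ccnc1` gives 4950 nM.
Compound 3 `CC1=C(/C=C/C(C)=C/C=C/C(C)=C\C(=O)Nc2ccccc2)C(C)(C)CCC1n1ccnc1` gives 1740 nM.

Compound 3 stands lowest of the three numbers. For the measured compounds named here, its nearest neighbour is compound 2, and the one measured step, a 2.8-fold lower number from compound 2 to compound 3 (0.45 log units; beyond the scatter), shows hydrogen in place of fluoro on an aromatic carbon. Going by the values given here, compound 1 lies furthest away; no step between compound 1 and compound 3 is described, so only their two values speak for that gap.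

The unmeasured compound 4 `CC1=C(/C=C/C(C)=C/C=C/C(C)=C\C(=O)NCc2ccccc2)C(C)(C)CCC1n1ccnc1` differs from compound 3 by a single change, (benzyl in place of phenyl on an amide-type nitrogen). Among the compounds with values here, none of the measured steps touches the amide-type nitrogen, so no step of the set bears directly on this change; the one step that exists concerns a fluoro substituent, not the group on the nitrogen. With nothing comparable on record, the expectation rests on compound 3 alone. The change from compound 3 to compound 4 is expected to stay near or just beyond the scatter, with a somewhat higher number more likely than a lower one, as a 1.6-fold higher number from compound 3 to compound 4 (0.21 log units; within the scatter). Compound 4 is therefore estimated at 2800 nM, within a range from 900 nM to 9000 nM.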

Compound 4, concentration for 50% growth inhibition: 5880 nM
Estimate against measurement, compound 4: 2.1-fold (0.32 log units) below, within the range that was stated.
By their numbers in this assay, from the lowest: compound 3; then compounds 2 and 4 (each within the scatter of the next); then compound 1.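

In this assay the group on the amide-type nitrogen proves able to move the number on its own: benzyl in place of phenyl gives a 3.4-fold higher number from compound 3 to compound 4 (0.53 log units; beyond the scatter) and so counts as a real step, although benzyl keeps the same aromatic ring and differs by 7 heavy atoms against 6. Benzyl in place of 4-fluorophenyl gives a 1.2-fold higher number from compound 2 to compound 4 (0.07 log units; within the scatter) and so cannot be told apart from the scatter, which leaves compound 3, with its plain phenyl, alone at the low end among the three compounds that share the rest of the structure. No measurement in hand explains why this nitrogen responds in this way.

The compounds shown leave open whether a longer chain such as phenethyl, or a methyl on the amide-type nitrogen in place of the amide hydrogen, would carry the number further in the same direction. They also leave open how 4-fluorobenzyl would read, and whether benzyl in place of phenyl would give a step of similar size on the core of compound 1.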